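Replacing a tert-Butyl Group with Methylsulfanyl

A few compounds are considered here, and "the series" means these few. Any claim that something is new, unique, unknown or untested is made for them only; others in the source may bear on it.

Among the compounds with values here, compound 1 `CCCc1cc(N)c2cc(NC(=O)/C=C/c3ccc(C(C)(C)C)cc3)ccc2n1` is one of two compounds measured in an assay on isolated protein for displacement of a labelled ligand from melanin-concentrating hormone receptor 1 (Homo sapiens); a higher number here means a weaker inhibitor, a lower number a stronger inhibitor; compound 1 gives 22 nM, the lower of the two numbers. Compound 2 `CCCc1cc(NC2CC2)c2cc(NC(=O)/C=C/c3ccc(C(F)(F)F)cc3)ccc2n1` gives 40 nM in this assay, a number within the usual scatter of that of compound 1. Compound 3 `CCCc1cc(N)c2cc(NC(=O)/C=C/c3ccc(SC)cc3)ccc2n1` has not yet been measured. It differs from compound 1 in one place: methylsulfanyl in place of tert-butyl on an aromatic carbon. Within the data shown here, no measured pair shows this change; the step is expected to be a 1.8-fold higher number from compound 1 to compound 3 (0.26 log units; within the scatter), small and toward a weaker inhibitor, possibly not beyond the scatter. Compound 3 is expected to give about 40 nM in this assay, within 15 nM to 120 nM.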

Compound 3, half-maximal inhibitory concentration: 9 nM
Beside the measured number, compound 3's estimate is 4.4-fold (0.65 log units) above it; measured number outside the range, below it.
By their numbers in this assay, from the lowest: compound 3; then compounds 1 and 2 (each within the scatter of the next).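

In this assay, methylsulfanyl in place of tert-butyl on this aromatic carbon gives a 2.4-fold lower number from compound 1 to compound 3 (0.39 log units; beyond the scatter) and so moves toward a stronger inhibitor. The tert-butyl group is therefore not required at this position, and a group with fewer heavy atoms, one of them sulfur, can take its place with a gain. Nothing available explains this gain. The compounds shown leave open whether the sulfur matters, since methoxy or a longer chain such as ethylsulfanyl on the same carbon would be needed to tell.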